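Working notes on a diacylglycerol lipase-alpha inhibitor pair

This account rests on a few compounds, and the source may have more. Where it says the series, first, only, none or still open, it means among the compounds named here.

Measured so far:
compound 1 `CCC1CCCCN1C(=O)n1ncc(-c2ccc(-c3ccccc3)cc2)n1` — 3980 nM
compound 2 `COc1ccc(CC2CCCCN2C(=O)n2ncc(C(O)(c3ccc(F)cc3)c3ccc(F)cc3)n2)cc1` — 5.01 nM

In an assay on HEK-293T cells for inhibition of diacylglycerol lipase-alpha (Homo sapiens), read by colorimetric assay (on this read-out higher numbers stand for weaker inhibition and lower numbers for stronger inhibition), compound 1 gives 3980 nM and compound 2 gives 5.01 nM. Compound 2 holds the lower of the two numbers, and its gap to compound 1 is beyond the scatter. Compound 3 `O=C(N1CCCCC1COc1ccc(F)cc1)n1ncc(C(O)(c2ccc(F)cc2)c2ccc(F)cc2)n1` differs from compound 2 by 4-fluorophenoxy in place of 4-methoxyphenyl on a saturated chain carbon bound to a saturated ring carbon. Among the compounds with values here, no measured pair shows a change of this kind, so the step size is uncertain; a small step is expected, within the scatter or slightly toward a higher number. The expected step is a 1.6-fold higher number from compound 2 to compound 3 (0.20 log units; within the scatter). Compound 3 is estimated at 8 nM, in a range from 2.5 nM to 25 nM.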

Compound 3, half-maximal inhibitory concentration: 5.01 nM
Estimate against measurement, compound 3: 1.6-fold (0.20 log units) above; measured number inside the range.
By their numbers in this assay, from the lowest: compounds 2 and 3 (each within the scatter of the next); then compound 1.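

In this assay, the exchange of 4-methoxyphenyl for 4-fluorophenoxy on a saturated chain carbon bound to a saturated ring carbon gives no change at the digits printed from compound 2 to compound 3 (within the scatter). Within the data shown here, this is the only single-place comparison, and it shows that the two groups are interchangeable at this position on this read-out, with the rest of the structure held constant. No available evidence bears on the reason for this result. Still open, going by these compounds, is whether an amine or a carboxylic acid at this place, or a longer chain, would leave the number equally unmoved.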